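Methoxy for difluoromethoxy: an estimate beside two limits

The source may report more compounds than this note shows. Statements on the series, on what has been measured and on what is new or still open speak of the compounds shown alone.

Compound 1 `COc1ccccc1OCCNc1cnn(Cc2ccc(OC(F)F)c(OCC3CC3)c2)c(=O)c1Cl` has been tested in a functional assay on SH-SY5Y cells (Homo sapiens) for antiproliferative activity, read by MTT assay, with a stated time of 48 h; a higher number here means a weaker inhibitor of growth, a lower number a stronger inhibitor of growth. In this assay compound 1 gives > 100000 nM, a limit of the assay rather than a number. Compound 2 `COc1ccccc1OCCNc1cnn(Cc2ccc(OC(F)F)c(OC3CCCC3)c2)c(=O)c1Cl` carries cyclopentyl in place of cyclopropylmethyl on an oxygen on an aromatic ring. In this assay compound 2 gives > 100000 nM, again a limit. The step that the two limits leave unreadable from compound 1 to compound 2 cannot be sized; what the series shows so far is the limit of > 100000 nM in this assay, at which 2 of the 2 values shown sit.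

Compound 3 `COc1ccccc1OCCNc1cnn(Cc2ccc(OC)c(OCC3CC3)c2)c(=O)c1Cl` differs from compound 1 by methyl in place of difluoromethyl on an oxygen on an aromatic ring. For the measured compounds named here, no measured step touches the difluoromethyl group, and the only measured step is unreadable. There is thus no basis for expecting movement in this assay in either direction beyond the scatter, and the most likely outcome for compound 3 is a further limit. Compound 3 is expected at 100000 nM, within 30000 nM to 300000 nM. For compound 3 the expected step is a number no higher from compound 1 to compound 3 (the limit leaves the size open).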

Compound 3, concentration for 50% growth inhibition: 37900 nM
The estimate for compound 3 lay 2.6-fold (0.42 log units) above the measured number; measured number inside the range.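

For the compounds shown here, this position is the first where a change gives a readable movement: in this assay, methyl in place of difluoromethyl on an oxygen on an aromatic ring gives an at least 2.6-fold lower number from compound 1 to compound 3 (0.42 log units; beyond the scatter). On these data alone, compound 1 stands at a limit of the assay, so this step fixes a minimum size only, and the full size stays unknown. Going by these compounds alone, compound 3 gives 37900 nM and is the only one of the three compounds with a number rather than a limit: the limit of > 100000 nM in this assay, at which 2 of the 3 values shown sit.

As far as these compounds go, whether the same change holds with cyclopentyl in place of cyclopropylmethyl remains open. Also open, from the compounds shown here alone, is how this assay responds to ethyl or trifluoromethyl in place of methyl on this oxygen.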